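Adding a 2-Carbamoylethyl Group to Compound 1

The source may hold more compounds than are shown below. What is called first, only, known or untested is meant among the compounds shown, and "the series" means these compounds.

Compound 1 `O=C(CN(c1nc(Cl)nc2[nH]cnc12)C1CC1)NCC(=O)OCc1ccccc1` stands lowest of the two compounds measured in a functional assay on the whole organism (Tail, strain ICR) with Mus musculus as the target, in the tail flick test, with a stated time of 30 min, at a dose of 25 umol/kg by the oral route; a lower number here means a weaker effect, a higher number a stronger effect of the compound at the dose given: compound 1 gives 18.7%, while compound 2 `C[C@H](NC(=O)CN(c1ncnc2c1ncn2C1CCCCO1)C1CC1)C(=O)OCc1ccccc1` gives 55.9%, a gap beyond the usual scatter. Within the data shown here, compound 2 differs from compound 1 in more than one place, so the two values show only that compound 2 reaches the higher number. Compound 3 `NC(=O)CC[C@H](NC(=O)CN(c1nc(Cl)nc2[nH]cnc12)C1CC1)C(=O)OCc1ccccc1` has not yet been measured in this assay. It differs from compound 1 in a single place: 2-carbamoylethyl in place of hydrogen on a saturated chain carbon bound to an amide-type nitrogen and a carbonyl carbon. Among the measured compounds shown here, no step between two measured compounds isolates this change, and the higher number of compound 2 offers only a loose hint. The account therefore expects a moderate rise in this assay, with wide uncertainty; the expected step is a number 11.3 percentage points higher from compound 1 to compound 3 (beyond the scatter). Compound 3 is estimated at 30%, with a range from 10% to 55%.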

Compound 3, a percentage reported as activity, at one dose (the size of the read-out at that dose, not a potency): 30.8%
Estimate against measurement, compound 3: 0.8 percentage points below, within the range that was stated.
By their numbers in this assay, from the lowest: compound 1; then compound 3; then compound 2.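

In this assay, placing 2-carbamoylethyl in place of hydrogen on a saturated chain carbon bound to an amide-type nitrogen and a carbonyl carbon gives a number 12.1 percentage points higher from compound 1 to compound 3 (beyond the scatter). Among these compounds, this is the first reading of a single change at this position, which the earlier pair, differing in more than one place, could not give, and it shows that this carbon can carry the chain with a modest gain in the read-out rather than a loss. No measurement among the data bears on why the number rises.

Going by these compounds, it remains open whether the gain belongs to the carbamoyl group or to the carbon chain that carries it, a question that a carboxylic acid or an amine in place of the carbamoyl, or a longer chain, would address. Also open, on these data alone, is whether the same change would give a similar step on the core of compound 2.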